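Two Ethylthio Groups on the Pyridine: Estimating Compound 3

The compounds below may be only part of what the source reports. "The series", "measured", "known", "first", "only" and "open" are said of these compounds alone.

Compound 2, `COc1cc([C@](O)(CCN(C)C)[C@@H](c2cc3cc(C#N)ccc3nc2OC)c2cccc(OC)c2F)cc(SC)n1`, is tested in an ADME assay on microsomes from liver (Mus musculus) for metabolic stability (on this read-out higher numbers stand for fast clearance and lower numbers for slow clearance), and gives 36 uL/min. Going by the values given here, compound 1, `COc1cc([C@](O)(CCN(C)C)[C@@H](c2cc3cc(Br)ccc3nc2OC)c2cccc(OC)c2F)cc(SC)n1`, gives 20 uL/min in this assay; the only measured step, a 1.8-fold higher number from compound 1 to compound 2 (0.26 log units; within the scatter), changes a different part of the molecule, and the two numbers sit within the scatter of each other. Compound 3, `CCSc1cc([C@](O)(CCN(C)C)[C@@H](c2cc3cc(C#N)ccc3nc2OC)c2cccc(OC)c2F)cc(SCC)n1`, differs from compound 2 by a group of 12 heavy atoms (9 carbon, 1 nitrogen, 2 sulfur; one six-membered aromatic ring with 1 hetero atom) in place of a group of 10 heavy atoms (7 carbon, 1 nitrogen, 1 oxygen, 1 sulfur; one six-membered aromatic ring with 1 hetero atom), on a saturated chain carbon bound to an oxygen on a saturated carbon and two saturated chain carbons. No measured step touches that place, so nothing shown sets a direction. Compound 3 is therefore expected close to compound 2, with an estimated step of a 1.3-fold higher number from compound 2 to compound 3 (0.10 log units; within the scatter) and wide bounds. The estimate for compound 3 in this assay is 45 uL/min, from 15 uL/min to 135 uL/min.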

Compound 3, intrinsic clearance in a liver preparation (reported as CLH), per the amount of preparation that the assay uses: 27 uL/min
The estimate for compound 3 lay 1.7-fold (0.22 log units) above the measured number; the measured number falls inside the stated range.
By their numbers in this assay, from the lowest: compounds 1, 3 and 2 (each within the scatter of the next).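

Going by these compounds alone, this step is the first measured change at this place, on a saturated chain carbon bound to an oxygen on a saturated carbon and two saturated chain carbons. In this assay, the group of 12 heavy atoms in place of the group of 10 heavy atoms gives a 1.3-fold lower number from compound 2 to compound 3 (0.12 log units; within the scatter), so this exchange does not move the read-out beyond the scatter. Nothing available explains this result. The compounds shown leave open whether a group carrying an amine or a carboxylic acid here, or a longer chain on sulfur, would shift clearance beyond the scatter.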